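A few compounds are considered here, and "the series" means these few. Any claim that something is new, unique, unknown or untested is made for them only; others in the source may bear on it.

Measured compounds:
- compound 1, `COc1ccc([C@@H]2C/C(=N/OCc3cn(-c4ccccc4CO)nn3)c3cc(CC=C(C)C)c(OC)cc3O2)cc1`: 100%
- compound 2, `COc1cc2c(cc1CC=C(C)C)C(=O)C[C@@H](c1ccc(Oc3ccccc3)cc1)O2`: 69%
- compound 3, `COc1cc2c(cc1CCC(C)C)C(=O)C[C@@H](c1ccc(O)cc1)O2`: 81%

All three were tested in a functional assay on MCF7 cells (Homo sapiens) for inhibition, read by sulforhodamine B assay, with a stated time of 48 h, tested at 50 uM; on this read-out higher numbers stand for more inhibition of growth at the one concentration tested and lower numbers for less inhibition of growth. Compound 1 stands highest of the three numbers; the nearest is compound 3, whose number is lower by an amount beyond the usual scatter, and the furthest is compound 2, lower still. Compound 4, `COc1ccc([C@@H]2C/C(=N/OCc3cn(-c4cc(OC)c(OC)c(OC)c4)nn3)c3cc(CC=C(C)C)c(OC)cc3O2)cc1`, has not yet been measured. It keeps the shared core and the five-membered ring with three nitrogens of compound 1, and differs from it in a single place: 3,4,5-trimethoxyphenyl in place of 2-(hydroxymethyl)phenyl on an aromatic nitrogen.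

For the measured compounds named here, no pair of measured compounds differs in only one place, so no measured step tells how this sort of exchange on the aromatic nitrogen plays out. Compound 1 already sits at the top of the scale in this assay, and a step from there can only hold or fall. The expectation for a number 8 percentage points lower from compound 1 to compound 4 (within the scatter) is a step no larger than the scatter, if any. Compound 4 is thus expected to give about 92%, in the range 72% to 100%.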

Compound 4, percent growth inhibition at one concentration: 45%
The estimate for compound 4 lay 47 percentage points above the measured number, outside the stated range (below it).
By their numbers in this assay, from the lowest: compound 4; then compound 2; then compound 3; then compound 1.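

In this assay, for the compounds shown here, the exchange of 2-(hydroxymethyl)phenyl for 3,4,5-trimethoxyphenyl on the aromatic nitrogen gives a number 55 percentage points lower from compound 1 to compound 4 (beyond the scatter) and is the first single change that can be read. The rest of the structure stays the same, so this whole step belongs to the group on that nitrogen, and one aromatic ring there cannot simply stand in for another. The change removes a hydrogen-bond donor, adds hydrogen-bond acceptors and enlarges the group, but no measurement here explains the drop.

One exchange cannot separate the loss of the hydroxymethyl group from the arrival of the three methoxy groups. Still open, from the compounds shown here alone, is how an unsubstituted phenyl, or a phenyl carrying an aminomethyl group or a carboxylic acid, would compare with compound 1 at 100% on this nitrogen.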